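This account rests on a few compounds, and the source may have more. Where it says the series, first, only, none or still open, it means among the compounds named here.

Three compounds have been measured in a functional assay on MCF7 cells (Homo sapiens) for antiproliferative activity, read by MTT assay, with a stated time of 48 h; a higher number here means a weaker inhibitor, a lower number a stronger inhibitor:

Compound 1 `C=C1[C@H](O)[C@@H](OC(=O)C(C)(C)C)[C@@H](O)C(C)(C)/C=C/[C@H](C)[C@H](OC(=O)c2ccccc2)[C@@]2(O)C[C@@](C)(O)[C@H](OC(C)=O)[C@@H]2[C@H]1OCC(C)C` gives 69900 nM.
Compound 2 `C=C1[C@H](O)[C@@H](OC(=O)c2cccc(C)c2)[C@@H](O)C(C)(C)/C=C/[C@H](C)[C@H](OC(=O)c2ccccc2)[C@@]2(O)C[C@@](C)(O)[C@H](OC(C)=O)[C@@H]2[C@H]1OCC(C)C` gives 63800 nM.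
Compound 3 `C=C1[C@H](OC(C)=O)[C@@H](OC(=O)C(C)(C)C)[C@@H](OC(C)=O)C(C)(C)/C=C/[C@H](C)[C@H](OC(=O)c2ccccc2)[C@@]2(O)C[C@@](C)(O)[C@H](OC(C)=O)[C@@H]2[C@H]1OCC(C)C` gives > 100000 nM.

For compound 3 the result in this assay is only a limit, not a number. Compound 2 differs from compound 1 by 3-methylphenyl in place of tert-butyl on a carbonyl carbon, and the step is a 1.1-fold lower number from compound 1 to compound 2 (0.04 log units; within the scatter). How the core of compound 3 differs from the core of compound 1 is not broken down here.

Compound 4 `C=C1[C@H](OC(C)=O)[C@@H](OC(=O)c2cccc(C)c2)[C@@H](OC(C)=O)C(C)(C)/C=C/[C@H](C)[C@H](OC(=O)c2ccccc2)[C@@]2(O)C[C@@](C)(O)[C@H](OC(C)=O)[C@@H]2[C@H]1OCC(C)C` has not yet been measured. It differs from compound 3 by 3-methylphenyl in place of tert-butyl on a carbonyl carbon, the same change seen from compound 1 to compound 2, made at the same place. That earlier step lay within the scatter, so the step from compound 3 to compound 4 is expected to be a number no higher from compound 3 to compound 4 (the limit leaves the size open). Compound 4 is therefore estimated at 100000 nM, and this assay may again report only a limit (the limit of > 100000 nM in this assay, at which 1 of the 3 values shown sits).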

Compound 4, half-maximal inhibitory concentration: 23400 nM
Compound 4: middle estimate off by 4.3-fold (0.63 log units), on the high side, and the stated range ends above it.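

In this assay, putting 3-methylphenyl in place of tert-butyl gives an at least 4.2-fold lower number from compound 3 to compound 4 (0.63 log units; beyond the scatter), so on this core the change has a clear effect. From the compounds shown here alone, compound 3 gives > 100000 nM, which is a limit and not a number, so the full size of this step stays unknown. The same change therefore does not carry over unaltered from the core of compound 1 to the core of compound 3, but two pairs give neither a general rule nor a reason for the gap: the same change on two cores in this assay, a 1.1-fold lower number (0.04 log units; within the scatter) from compound 1 to compound 2 and an at least 4.2-fold lower number (0.63 log units; beyond the scatter) from compound 3 to compound 4, at least 3.9-fold (0.59 log units) apart, beyond the scatter of two such steps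

The compounds shown leave open whether other groups on this carbonyl, such as a longer alkyl chain or a ring carrying an amine, would also behave differently on the two cores. They also leave open which part of the difference between the cores goes with the gap.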